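Removing a drawn stereocentre from a compound with a low number at adenosine A3

This account rests on a few compounds, and the source may have more. Where it says the series, first, only, none or still open, it means among the compounds named here.

Compound 1 `CC1=C(C(=O)OC(C)C)[C@H](c2ccco2)N/C(=N/C#N)N1` and compound 2 `CCOC(=O)C1=C(C)NC(=O)NC1C1CCCC1` were both tested in an assay on HeLa cells for displacement of a labelled ligand from adenosine receptor A3 (Homo sapiens), with a stated time of 180 min, tested at 1 uM; a higher number here means more inhibition at the concentration tested (going by the name of the read-out), a lower number less inhibition. Compound 1 gives 1%, the lower of the two numbers; compound 2 gives 18%, and the gap between the two lies beyond the usual scatter of this measurement.

Compound 3 `CC1=C(C(=O)OC(C)C)C(c2ccco2)N/C(=N/C#N)N1` has not yet been measured. Compared with compound 1, it differs only in how it is drawn: the two compounds have the same atoms and bonds; at least one stereo element is drawn with a configuration in one of them and without one in the other: 1 of 2 stereo elements differ; a stereocentre at a saturated ring carbon is drawn R in compound 1 and without a configuration in compound 3. The atoms and bonds are the same, so compound 3 most likely represents the material without a fixed configuration at that carbon, and compound 1 one of its two forms.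

Since compound 1 shows almost no inhibition, the step expected from compound 1 to compound 3 is a number 2 percentage points higher from compound 1 to compound 3 (within the scatter), that is, nothing beyond the scatter. For compound 3 the expected value in this assay is 3%, with a range from 0% to 15%.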

Compound 3, a percentage reported as inhibition, at one concentration (the size of the read-out at that concentration, not a potency): 4%
Beside the measured number, compound 3's estimate is 1 percentage points below it; the measured number falls inside the stated range.
By their numbers in this assay, from the lowest: compounds 1 and 3 (each within the scatter of the next); then compound 2.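

In this assay, the step is a number 3 percentage points higher from compound 1 to compound 3 (within the scatter), so at this saturated ring carbon, going from a drawn configuration to none leaves no difference that can be told from scatter. This is the first comparison shown in which the atoms and bonds stay the same and only the drawing of one carbon changes. The low numbers on both sides leave little room to see any preference between the forms at that carbon, and the only difference within the pair is: the fact that one of compounds 1 and 3 is drawn with a defined configuration and the other without, at the place where they differ

The compounds shown leave open how the opposite drawn form on its own would read, and whether the configuration at this carbon would count once the number is clearly higher. They also leave open whether an amine or a longer chain at this saturated ring carbon would change the inhibition.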